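A Silicon-Bearing Group Replaces Octyl on the Chain

The source may report more compounds than this note shows. Statements on the series, on what has been measured and on what is new or still open speak of the compounds shown alone.

Of the compounds shown here, three built on one shared core have been tested in a functional assay on HCT-116 cells (Homo sapiens) for antiproliferative activity, read by MTT assay, with a stated time of 48 h; a higher number here means a weaker inhibitor, a lower number a stronger inhibitor. Compound 1 (`CCC(CCO)n1cnc2c(Cl)nc(F)nc21`) gives 18900 nM, compound 2 (`CCCCC(CCO)n1cnc2c(Cl)nc(F)nc21`) gives 13500 nM and compound 3 (`CCCCCCCCCC(CCO)n1cnc2c(Cl)nc(F)nc21`) gives 32100 nM. Compound 3 thus lies within the scatter of compound 1 but stands apart from compound 2, by a modest margin: a 2.4-fold higher number from compound 2 to compound 3 (0.38 log units; beyond the scatter). The other two steps, a 1.4-fold lower number from compound 1 to compound 2 (0.15 log units; within the scatter) and a 1.7-fold higher number from compound 1 to compound 3 (0.23 log units; within the scatter), both stay within the scatter.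

Compound 4 (`CC(C)(C)[Si](C)(C)OCC(CCO)n1cnc2c(Cl)nc(F)nc21`) departs from compound 3 by a group of 8 heavy atoms (6 carbon, 1 oxygen, 1 silicon; no ring) in place of a group of 8 heavy atoms (8 carbon; no ring), on a saturated chain carbon, two bonds along the chain from an aromatic nitrogen. The octyl leaves, and the incoming group holds the same number of heavy atoms. All three measured steps alter only the length of a saturated chain, so none of them tests a group containing oxygen and silicon directly. Going by the values given here, they are the only guide, however, and the largest of them, a 2.4-fold higher number from compound 2 to compound 3 (0.38 log units; beyond the scatter), is modest. No large shift is therefore expected in this assay. The expected change is a 1.6-fold lower number from compound 3 to compound 4 (0.21 log units; within the scatter), a step that would not pass beyond the scatter. Compound 4 is estimated at 20000 nM, with an expected range of 9000 nM to 45000 nM.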

Compound 4, half-maximal inhibitory concentration: 7780 nM
Compound 4: the middle estimate sits 2.6-fold (0.41 log units) above what was measured; the whole stated range lies above it.
By their numbers in this assay, from the lowest: compounds 4, 2, 1 and 3 (each within the scatter of the next, the first and the last beyond it).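

In this assay this position, on a saturated chain carbon two bonds along the chain from an aromatic nitrogen, now shows its largest step in the set when octyl gives way to a group with the same number of heavy atoms, 6 carbon, 1 oxygen and 1 silicon (a 4.1-fold lower number from compound 3 to compound 4 (0.62 log units; beyond the scatter)). The earlier compounds shown here varied only the length of a saturated chain, so they could not show that a change in the atoms of the group, with heavy-atom count held, separates it from octyl beyond the scatter. Against the two shorter chains the result divides: one step stays within the scatter (a 1.7-fold lower number from compound 2 to compound 4 (0.24 log units; within the scatter)), while the other passes beyond it (a 2.4-fold lower number from compound 1 to compound 4 (0.39 log units; beyond the scatter)).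

Oxygen and silicon enter together in compound 4, so the compounds shown do not tell which of them, or whether the two together, goes with the step from octyl. A matching all-carbon chain with carbon in place of the silicon, or a free hydroxyl in place of the whole silicon-bearing group, would pull these apart. Nothing given here bears on the reason for the step.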